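Halophenyl benzylamine variants on a shared core: tolerance notes

A few compounds are considered here, and "the series" means these few. Any claim that something is new, unique, unknown or untested is made for them only; others in the source may bear on it.

In an ADME assay on Huh-7 cells (Homo sapiens) for cytotoxicity (a higher number here means that more compound is tolerated, a lower number that less compound is tolerated), the measured compounds stand as follows.
Compound 1 `O=c1cc(CNCc2ccccc2O)oc2ccc(O)c(O)c12` gives > 100000 nM, a limit of the assay.
Compound 2 `O=c1cc(CNCc2cccc(Cl)c2)oc2ccc(O)c(O)c12` gives > 100000 nM, a limit of the assay.
Compound 3 `O=c1cc(CNCc2cccc(I)c2)oc2ccc(O)c(O)c12` gives > 100000 nM, a limit of the assay.

Compound 3 sits at the limit of > 100000 nM in this assay, at which 3 of the 3 values shown sit. Among the measured compounds shown here, no measured compound has yet returned a number rather than a limit, so compound 3 cannot be ranked against compound 1 or compound 2 within the assay.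

The next compound, compound 4 `O=c1cc(CNCc2ccc(Cl)cc2)oc2ccc(O)c(O)c12`, differs from compound 3 by 4-chlorophenyl in place of 3-iodophenyl on a saturated chain carbon bound to an amine nitrogen. For the measured compounds named here, three measured steps bear on this change. The step that the two limits leave unreadable from compound 1 to compound 2 and the step that the two limits leave unreadable from compound 1 to compound 3 exchange the whole aryl group on that carbon, and the step that the two limits leave unreadable from compound 2 to compound 3 exchanges one halogen for another on the aromatic carbon; none of the three can be sized, since both ends of each lie at the limit. A halogenated phenyl on the saturated chain carbon bound to the amine nitrogen has therefore not yet produced a readable value in this assay.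

The expected step that the limit leaves unreadable from compound 3 to compound 4 is accordingly no readable change beyond the scatter. Compound 4 is estimated at 150000 nM, with a range of 50000 nM to 500000 nM, most likely reported again as a limit.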

Compound 4, half-maximal cytotoxic concentration: > 100000 nM
Compound 4 gave a limit, no number; the forecaster's own chance of this, stated with the estimate: 85%; the middle value does not contradict the limit.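

In this assay compound 4 gives > 100000 nM, again a limit of the assay and not a number. Its steps from compound 1, compound 2 and compound 3 cannot be read: the limit of > 100000 nM in this assay, at which 4 of the 4 values shown sit.

The compounds shown leave open at what concentration any of them becomes cytotoxic, and whether 2-hydroxyphenyl, 3-chlorophenyl, 3-iodophenyl and 4-chlorophenyl differ at all.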